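From pentyl to cyclohexyloxy at the assay limit

The compounds below may be only part of what the source reports. "The series", "measured", "known", "first", "only" and "open" are said of these compounds alone.

Measured in an ADME assay on microsomes from liver (Homo sapiens) for metabolic stability, read by LC-MS, with NADPH named in the record, with a stated time of 60 min, tested at 1 uM, in the absence of a further agent; a higher number here means that more of the compound is left, a lower number that less of the compound is left:
Compound 1 `COc1ccc(-c2c(C)nc3c(N4CC[C@@H](NC(C)=O)C4)cc(C)nn23)cn1` gives > 95% as a limit.
Compound 2 `CCCCCC(=O)N[C@@H]1CCN(c2cc(C)nn3c(-c4ccc(OC)c(OC)c4)c(C)nc23)C1` gives > 95% as a limit.

Neither compound has an exact number, and the two cannot be ranked. Compound 2 stands at the limit of this assay, not at a measured value, and it shares that position with compound 1 (the limit of > 95% in this assay, at which 2 of the 2 values shown sit).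

Compound 3 `COc1ccc(-c2c(C)nc3c(N4CC[C@@H](NC(=O)OC5CCCCC5)C4)cc(C)nn23)cc1OC` has not yet been measured. It differs from compound 2 by one change, cyclohexyloxy in place of pentyl on a carbonyl carbon. For the measured compounds named here, no measured step between compounds shows what such a change does, so the expectation rests on compound 2, whose limit is > 95%. A small fall, perhaps within the usual scatter, is expected, and the estimated step is a number at least 7 percentage points lower from compound 2 to compound 3 (that floor lies within the scatter). For compound 3 the expected value is 88%, with an estimated range from 65% to 100%.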

Compound 3, percent of the compound remaining: > 95%
Compound 3 gave a limit, no number (the forecaster's own chance of this, stated with the estimate: 45%); middle value at least 7 percentage points from the limit.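

No step can be read from compound 2 to compound 3 in this assay, as both give a limit and not an exact number: the limit of > 95% in this assay, at which 3 of the 3 values shown sit.

The compounds shown leave open whether cyclohexyloxy in place of pentyl on a carbonyl carbon changes how much of the compound is left.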